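The source may hold more compounds than are shown below. What is called first, only, known or untested is meant among the compounds shown, and "the series" means these compounds.

In an assay for inhibition of protein disulfide-isomerase (Homo sapiens), with a stated time of 1 h (a lower number here means a stronger inhibitor, a higher number a weaker inhibitor), compound 2 `Cc1ccnc(NC(c2ccc(F)cc2)c2ccc3cccnc3c2O)c1` gives 140 nM, the lowest of the two numbers shown. Compound 1 `Cc1ccnc(NC(c2ccc(C(F)(F)F)cc2)c2ccc3cccnc3c2O)c1` gives 26500 nM, and the step of a 190-fold lower number from compound 1 to compound 2 (2.28 log units; beyond the scatter) is large. Compound 3 `Cc1ccnc(NC(c2ccccc2)c2ccc3cccnc3c2O)c1` gives only a limit, < 200 nM. The step of an at least 130-fold lower number from compound 1 to compound 3 (2.12 log units; beyond the scatter) is also large, whereas the step that the limit leaves unreadable from compound 2 to compound 3 cannot be read. Compound 4 `Oc1c(C(c2ccc(F)cc2)N2CCCCC2)ccc2cccnc12` differs from compound 2 by piperidin-1-yl in place of (4-methylpyridin-2-yl)amino on a saturated chain carbon bound to two aromatic carbons. For the measured compounds named here, none of the measured steps touches that saturated carbon; all three concern an aromatic carbon of the other ring, so no measured step bears on this change. The estimate for compound 4 is therefore uncertain, and a step of a 4.3-fold higher number from compound 2 to compound 4 (0.63 log units; beyond the scatter) is expected. Compound 4 is estimated at 600 nM, within the range 100 nM to 6000 nM.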

Compound 4, half-maximal inhibitory concentration: 690 nM
Beside the measured number, compound 4's estimate is 1.2-fold (0.06 log units) below it; low and high end bracket the measured number.
By their numbers in this assay, from the lowest: compound 2; then compound 4; then compound 1.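

In this assay, replacing (4-methylpyridin-2-yl)amino with piperidin-1-yl on the saturated chain carbon gives a 4.9-fold higher number from compound 2 to compound 4 (0.69 log units; beyond the scatter), a modest step. For the compounds shown here, this is the first reading at this position, and it shows that the aromatic ring and the hydrogen-bond donor of the leaving group can both go at a modest cost in this pair. Nothing measured here accounts for the size of this step. Going by these compounds, it remains open how morpholin-4-yl or an open-chain amine such as diethylamino would read at this carbon.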